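A few compounds are considered here, and "the series" means these few. Any claim that something is new, unique, unknown or untested is made for them only; others in the source may bear on it.

Compound 1 `COc1ccc(C(O)(C/C=C\c2ccccc2)c2cccc3ccccc23)c(OC)c1OC` and compound 2 `COc1ccc(C(c2ccc(OCCO)cc2)c2cccc3ccccc23)c(OC)c1OC` share one core, and in a functional assay on A549 cells (Homo sapiens) for inhibition, read by sulforhodamine B assay, with a stated time of 48 h (a lower number here means a stronger inhibitor, a higher number a weaker inhibitor), both are weak. Compound 1 gives 17600 nM there. For compound 2 this assay reports only a limit, > 20000 nM, which is the limit of > 20000 nM in this assay, at which 1 of the 2 values shown sits. Compound 3 `COc1ccc(C(OCc2ccc(C)cc2)c2cccc3ccccc23)c(OC)c1OC` differs from compound 2 in one place: (4-methylbenzyl)oxy in place of 4-(2-hydroxyethoxy)phenyl on a saturated chain carbon bound to two aromatic carbons. Among the compounds with values here, since no measured step of this kind exists, the expected step of an at least 1.3-fold lower number from compound 2 to compound 3 (0.12 log units; that floor lies within the scatter) is small, within the scatter or a slight gain in potency. Compound 3 is therefore estimated at about 15000 nM in this assay, plausibly between 5000 nM and 40000 nM.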

Compound 3, half-maximal inhibitory concentration: 15700 nM
Compound 3: middle estimate off by 1.0-fold (0.02 log units), on the low side; measured number inside the range.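

In this assay, placing (4-methylbenzyl)oxy where 4-(2-hydroxyethoxy)phenyl stood on a saturated chain carbon bound to two aromatic carbons gives an at least 1.2-fold lower number from compound 2 to compound 3 (0.10 log units; that floor lies within the scatter). The value for compound 2 is a limit, so this step has only a floor: the limit of > 20000 nM in this assay, at which 1 of the 3 values shown sits. The change therefore yields a measured but still weak number for compound 3, with no clear gain in potency.

On these data alone, whether an amine or a carboxylic acid on that same chain carbon would give a stronger inhibitor stays open. As far as these compounds go, the true size of the step also stays open.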